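Moving a Halogen, Then Swapping It for a Nitrile

The source may report more compounds than this note shows. Statements on the series, on what has been measured and on what is new or still open speak of the compounds shown alone.

Measured compounds:
- compound 1 `CN(C)C(=O)c1cc2cnc(Nc3ccc(NC(=O)C4(C(=O)Nc5ccc(Br)cc5)CC4)cc3)nc2n1C1CCCC1` gives -6.6%
- compound 2 `CN(C)C(=O)c1cc2cnc(Nc3ccc(NC(=O)C4(C(=O)Nc5cccc(Br)c5)CC4)cc3)nc2n1C1CCCC1` gives 20.2%

Both compounds were tested in a functional assay on A549 cells (Homo sapiens) for inhibition, read by CCK-8 assay, with a stated time of 72 h, tested at 1 uM; on this read-out higher numbers stand for more inhibition of growth at the one concentration tested and lower numbers for less inhibition of growth. Of the two numbers, compound 1 stands lowest; its nearest neighbour is compound 2, and the step of a number 26.8 percentage points higher from compound 1 to compound 2 (beyond the scatter) arises from 3-bromophenyl in place of 4-bromophenyl on an amide-type nitrogen.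

Compound 3 `CN(C)C(=O)c1cc2cnc(Nc3ccc(NC(=O)C4(C(=O)Nc5cccc(C#N)c5)CC4)cc3)nc2n1C1CCCC1` has not yet been tested in this assay. It differs from compound 1 as follows: 3-cyanophenyl in place of 4-bromophenyl on an amide-type nitrogen.

Among the measured compounds shown here, only the step from compound 1 to compound 2 bears on this change, and only in part: it shows that moving the substituent on this phenyl from the 4-position to the 3-position gave a modest rise in growth inhibition. For the measured compounds named here, compound 3 also carries its substituent at the 3-position, but no measured pair shows what a nitrile does in place of bromine, so that part of the change remains unanchored. On balance a modest upward step a number 16.6 percentage points higher from compound 1 to compound 3 (beyond the scatter) is expected, with wide uncertainty. Compound 3 is therefore estimated at 10% in this assay, within a range from -12% to 32%.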

Compound 3, percent growth inhibition at one concentration: 70.8%
The estimate for compound 3 lay 60.8 percentage points below the measured number, and the stated range ends below it.
By their numbers in this assay, from the lowest: compound 1; then compound 2; then compound 3.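

Among the compounds shown here, on the phenyl ring of this amide, the earlier pair showed only that moving bromine changes the read-out. Compound 3 shows that the group itself also counts: with the substituent kept at the 3-position, the change of cyano in place of bromo on an aromatic carbon gives a number 50.6 percentage points higher from compound 2 to compound 3 (beyond the scatter) in this assay. Taken as a whole, 3-cyanophenyl in place of 4-bromophenyl on an amide-type nitrogen gives a number 77.4 percentage points higher from compound 1 to compound 3 (beyond the scatter), a large shift in this assay from a change at a single site, though nothing available here speaks to what lies behind it.

The compounds shown leave open whether the rise belongs to the nitrile specifically, since a methoxy group, an amine or a carboxylic acid at the same ring position could give a lower, similar or higher number. They also leave open whether a nitrile would perform as well where bromine sits in compound 1, and, with one concentration as the only read-out, how growth inhibition would change at other concentrations.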